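The compounds below may be only part of what the source reports. "The series", "measured", "known", "first", "only" and "open" are said of these compounds alone.

Among the measured compounds shown here, in a functional assay (spleen, spleen) for activation, with Mus musculus as the target (a lower number here means that less compound is needed, a higher number that more compound is needed for the effect), the three compounds measured so far share one core and differ only in the group on one aromatic carbon. Compound 1 `CNc1nc(N)c2nc(O)n(Cc3ccccc3)c2n1`, carrying methylamino there, gives 1 uM. Compound 2 `CCCCc1nc(N)c2nc(O)n(Cc3ccccc3)c2n1`, carrying butyl, gives 0.03 uM. Compound 3 `CCCC[S+]([O-])c1nc(N)c2nc(O)n(Cc3ccccc3)c2n1` gives 0.01 uM and stands lowest of the three: the step of a 3.0-fold lower number from compound 2 to compound 3 (0.48 log units; beyond the scatter) is modest, while the step of a 100-fold lower number from compound 1 to compound 3 (2.00 log units; beyond the scatter) is large.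

Compound 4 `CSc1nc(N)c2nc(O)n(Cc3ccccc3)c2n1` is not yet measured. Its change from compound 3 is a group of 2 heavy atoms (1 carbon, 1 sulfur; no ring) in place of a group of 6 heavy atoms (4 carbon, 1 oxygen, 1 sulfur; no ring), on an aromatic carbon. For the measured compounds named here, two measured steps bear on this: the step of a 100-fold lower number from compound 1 to compound 3 (2.00 log units; beyond the scatter) shows that replacing a two-atom group with the six-atom group lowered the number greatly, and the step of a 3.0-fold lower number from compound 2 to compound 3 (0.48 log units; beyond the scatter) shows a modest lowering even from the four-carbon chain. Going back to a two-atom group is therefore expected to raise the number substantially, in the direction of compound 1, although methylsulfanyl is not methylamino and no direct step tells the difference. For compound 4 the expected step is a 30-fold higher number from compound 3 to compound 4 (1.48 log units; beyond the scatter), giving an estimate of 0.3 uM with a range from 0.05 uM to 2 uM.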

Compound 4, minimum effective concentration: 0.1 uM
Estimate against measurement, compound 4: 3.0-fold (0.48 log units) above; the range from low to high includes it.
By their numbers in this assay, from the lowest: compound 3; then compound 2; then compound 4; then compound 1.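

In this assay, methylsulfanyl and methylamino have the same number of heavy atoms, yet there is a 10-fold lower number from compound 1 to compound 4 (1.00 log units; beyond the scatter), so at this carbon between two ring nitrogen atoms the identity of the attached group matters, not only its size. The short sulfur group does not match the larger groups either, with a 3.3-fold higher number from compound 2 to compound 4 (0.52 log units; beyond the scatter) and a 10-fold higher number from compound 3 to compound 4 (1.00 log units; beyond the scatter), so the sulfur atom alone does not give the lowest numbers seen here. No measurement is available that explains these differences.

On these data alone, compound 3 differs from compound 4 in both chain length and the oxygen on sulfur, so the share of each in that step remains unknown. Butylsulfanyl, which has the butyl chain on sulfur without the oxygen, would separate the two, and butylamino would test the linking atom at the same chain length.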